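Dropping tert-butoxycarbonyl from a protected polyamine: cell toxicity

This account rests on a few compounds, and the source may have more. Where it says the series, first, only, none or still open, it means among the compounds named here.

Compound 1 `CC(C)(C)OC(=O)NCCCCNCCCN(Cc1ccccc1)Cc1ccccc1` carries a tert-butoxycarbonyl group on one of its amine nitrogens, and compound 3 `NCCCCNCCCN(Cc1ccccc1)Cc1ccccc1` is the same molecule with a hydrogen in its place. In an ADME assay on RAW264.7 cells (Mus musculus) for cytotoxicity, read by resazurin assay, with a stated time of 48 h (on this read-out higher numbers stand for lower toxicity in this test and lower numbers for higher toxicity in this test), compound 1 gives 12500 nM. In this assay compound 3 gives 17700 nM. The change hydrogen in place of tert-butoxycarbonyl on an amine nitrogen thus produced a 1.4-fold higher number from compound 1 to compound 3 (0.15 log units; within the scatter), so the two readings cannot be told apart with confidence.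

Compound 2 `CC(C)(C)OC(=O)NCCCCNCCCN(Cc1cccc(-c2ccccc2)c1)Cc1cccc(-c2ccccc2)c1` keeps the tert-butoxycarbonyl group on a different core; how its core differs from that of compound 1 is not broken down here. In this assay compound 2 gives only a limit, > 100000 nM, which is the limit of > 100000 nM in this assay, at which 1 of the 3 values shown sits. Compound 4 `NCCCCNCCCN(Cc1cccc(-c2ccccc2)c1)Cc1cccc(-c2ccccc2)c1` is compound 2 after the same change, (hydrogen in place of tert-butoxycarbonyl on an amine nitrogen), made at a place described in the same words, so it is the same change. Because the same change earlier gave a 1.4-fold higher number from compound 1 to compound 3 (0.15 log units; within the scatter), the expected step is similarly small, a step that the limit leaves unreadable from compound 2 to compound 4. Compound 4 is therefore estimated to give 150000 nM, with a likely range from 60000 nM to 400000 nM, and the measurement may again come back only as a limit.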

Compound 4, half-maximal cytotoxic concentration: 30300 nM
Compound 4: the middle estimate sits 5.0-fold (0.69 log units) above what was measured; the whole stated range lies above it.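

On the core of compound 2, putting hydrogen in place of tert-butoxycarbonyl gave an at least 3.3-fold lower number from compound 2 to compound 4 (0.51 log units; beyond the scatter), a shift toward higher toxicity in this test, so the change did not carry over unaltered from one core to the other: the same change on two cores in this assay, a 1.4-fold higher number (0.15 log units; within the scatter) from compound 1 to compound 3 and an at least 3.3-fold lower number (0.51 log units; beyond the scatter) from compound 2 to compound 4, at least 4.6-fold (0.66 log units) apart, beyond the scatter of two such steps

The reading for compound 2, > 100000 nM, is a limit of the assay and not a number.

The full size of that step therefore stays unknown, and a comparison of two cores shows neither why they part ways nor what the change would do on a third core.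

The compounds shown leave open whether an acetyl group or a methoxycarbonyl group on the same amine nitrogen would behave like tert-butoxycarbonyl on each core. They also leave open whether a simple methyl group or a longer chain on that nitrogen would give a reading closer to that of the free amine or to that of the protected compound.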